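The source may hold more compounds than are shown below. What is called first, only, known or untested is meant among the compounds shown, and "the series" means these compounds.

In an ADME assay on HaCaT cells (Homo sapiens) for cytotoxicity, read by MTT assay, with a stated time of 48 h (a higher number here means a weaker inhibitor, a lower number a stronger inhibitor), compound 1 (`Clc1ccc2[nH]c(-c3cn(-c4ccccc4)nc3-c3ccccc3)nc2c1`) reports only a limit (> 50000 nM). Compound 3 (`Clc1ccc(-c2nn(-c3ccccc3)cc2-c2nc3ccccc3[nH]2)cc1`), which carries the 4-chlorophenyl, also reports only a limit (> 50000 nM). Among the measured compounds shown here, compound 2 (`Clc1cc2nc(-c3cn(-c4ccccc4)nc3-c3ccccc3)[nH]c2cc1Cl`) gives 29700 nM as the only actual number of the three. Compound 4 (`Clc1ccc(-c2nn(-c3ccccc3)cc2-c2nc3cc(Cl)c(Cl)cc3[nH]2)cc1`) departs from compound 2 by turning phenyl into 4-chlorophenyl, with chloro in place of hydrogen on an aromatic carbon. For the measured compounds named here, the one measured step of this kind is an at least 1.6-fold lower number from compound 1 to compound 2 (0.22 log units; that floor lies within the scatter), and its floor lies within the scatter. Only a slight move to a lower number is therefore expected, with no step beyond the scatter (a 1.2-fold lower number from compound 2 to compound 4 (0.07 log units; within the scatter)). In this assay compound 4 is estimated at 25000 nM, with a range from 11000 nM to 50000 nM.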

Compound 4, half-maximal inhibitory concentration: > 50000 nM
Compound 4: only a limit was reported; the forecaster's own chance of this, stated with the estimate: 25%; at least 2.0-fold (0.30 log units) between middle value and limit.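

In this assay the same kind of change, chloro in place of hydrogen on an aromatic carbon, now sits para to a large group, and the step there is an at least 1.6-fold higher number from compound 2 to compound 4 (0.22 log units; that floor lies within the scatter) whereas the earlier step was an at least 1.6-fold lower number from compound 1 to compound 2 (0.22 log units; that floor lies within the scatter). Neither floor lies beyond the scatter, so the two steps show no common direction for this change. Compound 4 reports only a limit, so the size of the step stays unread, and the reading is bounded by the assay's ceiling: the limit of > 50000 nM in this assay, at which 3 of the 4 values shown sit. As far as these compounds go, whether an amine or a carboxylic acid at this place would give a number under that limit in this assay stays open.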